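A thiophene ring in place of a methylsulfanyl group

This account rests on a few compounds, and the source may have more. Where it says the series, first, only, none or still open, it means among the compounds named here.

Three compounds share one core. Compound 1 `O=C1NCCN(c2cccc(Cl)c2)N1` gives, in a functional assay on cells for inhibition of Polyunsaturated fatty acid 5-lipoxygenase (Homo sapiens) (on this read-out higher numbers stand for weaker inhibition and lower numbers for stronger inhibition), 2100 nM. Compound 2 `CSc1cccc(N2CCNC(=O)N2)c1` gives 2200 nM, and compound 3 `CC1CN(c2cccc(F)c2)NC(=O)N1` gives 1800 nM. The number of compound 2 is the largest of the three, but the step of a 1.0-fold higher number from compound 1 to compound 2 (0.02 log units; within the scatter) lies within the scatter, as does the gap between compound 2 and compound 3, so nothing separates these three on this read-out.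

Compound 4 `O=C1NCCN(c2cccc(-c3ccsc3)c2)N1` differs from compound 2 by thiophen-3-yl in place of methylsulfanyl on an aromatic carbon. Among the compounds with values here, only one measured step bears on this position: the exchange of chloro for methylsulfanyl from compound 1 to compound 2, which left the number unchanged within the scatter. Within the data shown here, no measured compound carries a thiophen-3-yl group or any other ring at this place, so the size of this step has no direct precedent. Given that one exchange at this position moved nothing, compound 4 is expected to sit close to compound 2, with a step of a 1.2-fold lower number from compound 2 to compound 4 (0.06 log units; within the scatter) that stays within the scatter. Compound 4 is therefore estimated at 1900 nM, between 600 nM and 6000 nM.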

Compound 4, half-maximal inhibitory concentration: 5300 nM
Compound 4: middle estimate off by 2.8-fold (0.45 log units), on the low side; measured number inside the range.
By their numbers in this assay, from the lowest: compounds 3, 1 and 2 (each within the scatter of the next); then compound 4.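

This position does not tolerate every exchange equally. Chloro and methylsulfanyl could not be told apart here, but in this assay thiophen-3-yl, the only ring shown at this place, gives a 2.4-fold higher number from compound 2 to compound 4 (0.38 log units; beyond the scatter) and a 2.5-fold higher number from compound 1 to compound 4 (0.40 log units; beyond the scatter), so inhibition is modestly weaker than with either of the two non-ring groups, and both steps lie beyond the scatter. No measured evidence bears on the reason for this rise.

The compounds shown leave open whether the rise goes with any ring at this place or with thiophen-3-yl alone, a question that a phenyl ring, a furan ring or a longer chain such as butyl could address. Also open, as far as these compounds go, is whether thiophen-3-yl gives the same step on the methyl-bearing core of compound 3.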